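The compounds below may be only part of what the source reports. "The series", "measured", "known", "first", "only" and "open" are said of these compounds alone.

Values in a functional assay on HepG2 cells (Homo sapiens) for antiproliferative activity, read by MTT assay, with a stated time of 48 h; a lower number here means a stronger inhibitor, a higher number a weaker inhibitor:
Compound 1 `COc1ccc(CN(C(=O)Cn2cc(COc3cc(=O)oc4ccccc34)nn2)c2cc(OC)c(OC)c(OC)c2)cc1`: 6250 nM
Compound 2 `COc1ccc(CN(C(=O)Cn2cc(COc3ccccc3)nn2)c2cc(OC)c(OC)c(OC)c2)cc1`: 20500 nM
Compound 3 `COc1ccc(CN(C(=O)Cn2cc(CSc3nnnn3C)nn2)c2cc(OC)c(OC)c(OC)c2)cc1`: 28300 nM

Compound 3 cannot be told apart from compound 2, as a 1.4-fold higher number from compound 2 to compound 3 (0.14 log units; within the scatter) shows. Compound 1 stands clearly apart from both, through a 3.3-fold higher number from compound 1 to compound 2 (0.52 log units; beyond the scatter) and a 4.5-fold higher number from compound 1 to compound 3 (0.66 log units; beyond the scatter), each of them modest.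

Compound 4 `COc1ccc(CN(C(=O)Cn2cc(Cn3ccc4ccccc43)nn2)c2cc(OC)c(OC)c(OC)c2)cc1` differs from compound 3 in one place: 1H-indol-1-yl in place of (1-methyl-1H-tetrazol-5-yl)sulfanyl on a saturated chain carbon bound to an aromatic carbon. Here 1H-indol-1-yl replaces (1-methyl-1H-tetrazol-5-yl)sulfanyl on a saturated chain carbon bound to an aromatic carbon.

Swapping one single-ring group for another changed little in a 1.4-fold higher number from compound 2 to compound 3 (0.14 log units; within the scatter). Only compound 1 carries a group with two aromatic rings, as 1H-indol-1-yl also does, and a 4.5-fold higher number from compound 1 to compound 3 (0.66 log units; beyond the scatter) is the closest guide. Three compounds make thin evidence, and the indole lacks the oxygen link of compound 1, so only part of that step is expected to carry over in this assay. The expected change is modest and toward a lower number: a 2.2-fold lower number from compound 3 to compound 4 (0.34 log units; beyond the scatter). For compound 4 the estimated value is 13000 nM, with an expected range of 5000 nM to 32000 nM.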

Compound 4, half-maximal inhibitory concentration: 40100 nM
For compound 4 the middle estimate is 3.1-fold (0.49 log units) below the measured one; measured number above the stated range.
By their numbers in this assay, from the lowest: compound 1; then compounds 2, 3 and 4 (each within the scatter of the next).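

A second aromatic ring at this position is not enough on its own to bring a compound close to compound 1: the two-ring 1H-indol-1-yl group leaves compound 4 with a 6.4-fold higher number from compound 1 to compound 4 (0.81 log units; beyond the scatter). It does not separate compound 4 from the single-ring compounds, with a 1.4-fold higher number from compound 3 to compound 4 (0.15 log units; within the scatter) and a 2.0-fold higher number from compound 2 to compound 4 (0.29 log units; within the scatter), so among the four compounds only the group of compound 1 stands apart. No measurement shown here accounts for this result.

Going by these compounds, whether the edge of compound 1 depends on its oxygen link, on the oxygen atoms of its two-ring group or on both remains open. Also open, on these data alone, is how a simple amine or a carboxylic acid on this saturated chain carbon would compare.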